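Benzyl triazole series: iodophenyl replacing methylphenyl

This account rests on a few compounds, and the source may have more. Where it says the series, first, only, none or still open, it means among the compounds named here.

Measured so far:
compound 1 `O=C1N[C@H]2[C@H](CS[C@H]2CCCCCc2cn(Cc3ccccc3O)nn2)N1` — a limit in an assay on isolated protein for inhibition of biotin--protein ligase (Homo sapiens), read by scintillation counting, with a stated time of 10 min; on this read-out lower numbers stand for stronger inhibition and higher numbers for weaker inhibition: compound 1 gives > 16000 nM.
compound 2 `Cc1cccc(Cn2cc(CCCCC[C@@H]3SC[C@@H]4NC(=O)N[C@@H]43)nn2)c1` — a limit in this assay: compound 2 gives > 16000 nM.

Compound 2 stands only at a limit of this assay, with no number behind it. Among the compounds with values here, the single step recorded, a step that the two limits leave unreadable from compound 1 to compound 2, is unreadable because of the limit of > 16000 nM in this assay, at which 2 of the 2 values shown sit, so no direction or size can be drawn from it.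

Compound 3 `O=C1N[C@H]2[C@H](CS[C@H]2CCCCCc2cn(Cc3ccc(I)cc3)nn2)N1` has not yet been measured in this assay. It differs from compound 2 by 4-iodophenyl in place of 3-methylphenyl on a saturated chain carbon bound to an aromatic nitrogen. Within the data shown here, the one measured step bears on the same chain carbon but gives no readable size, so for compound 3 the expected step that the limit leaves unreadable from compound 2 to compound 3 is no readable change, most likely another limit. The estimate for compound 3 in this assay is therefore 30000 nM, with a range from 8000 nM to 120000 nM.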

Compound 3, inhibition constant: > 16000 nM
Compound 3: a limit, no number (the forecaster's own chance of this, stated with the estimate: 75%); the middle value does not contradict the limit.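

No step among compound 1, compound 2 and compound 3 can be read, because all three rest on the same limit: the limit of > 16000 nM in this assay, at which 3 of the 3 values shown sit.

Still open, on these data alone, is what number lies behind each limit in this assay, and so whether 2-hydroxyphenyl, 3-methylphenyl and 4-iodophenyl differ at all.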